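The source may report more compounds than this note shows. Statements on the series, on what has been measured and on what is new or still open speak of the compounds shown alone.

Compound 2 has the structure `Fc1ccc(-n2c(S)nnc2Sc2nnc(-c3ccccc3)n2-c2ccccc2)cc1`. In a functional assay on HT-29 cells (Homo sapiens) for inhibition, read by MTT assay, with a stated time of 48 h (a higher number here means a weaker inhibitor, a lower number a stronger inhibitor), compound 2 gives a half-maximal inhibitory concentration of 32800 nM. Compound 3, with the structure `Sc1nnc(CSc2nnc(-c3ccccc3)n2-c2ccccc2)n1-c1ccc(Cl)cc1`, gives 36600 nM in this assay, and the two numbers lie within the usual scatter of each other, so neither can be called the weaker or the stronger of the pair. For compound 1, with the structure `CCOc1ccc(-n2c(S)nnc2CSc2nnc(-c3ccccc3)n2-c2ccccc2)cc1`, the result in this assay is "not determined" (no result reported). Compound 4, with the structure `Sc1nnc(Sc2nnc(-c3ccccc3)n2-c2ccccc2)n1-c1ccc(Cl)cc1`, has not yet been measured. It differs from compound 2 in one place: chloro in place of fluoro on an aromatic carbon. Among the compounds with values here, no measured pair in this set shows the same change on its own, so the size of the step can only be judged from compound 3, which carries the same chloro group on that ring and gives 36600 nM. On that basis the step from compound 2 to compound 4 in this assay is expected to be no larger than the scatter, in either direction, namely a 1.1-fold higher number from compound 2 to compound 4 (0.03 log units; within the scatter). Compound 4 is therefore expected to give about 35000 nM in this assay, with a plausible range from 15000 nM to 80000 nM.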

Compound 4, half-maximal inhibitory concentration: 38400 nM
Compound 4: the middle estimate sits 1.1-fold (0.04 log units) below what was measured; measured number inside the range.
By their numbers in this assay, from the lowest: compounds 2, 3 and 4 (each within the scatter of the next).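

In this assay, within the data shown here, the step of a 1.2-fold higher number from compound 2 to compound 4 (0.07 log units; within the scatter) gives the first direct reading of this change, as no earlier measured pair isolated it. On this aromatic carbon, para to a large group, 4-fluorophenyl and 4-chlorophenyl therefore cannot be told apart, since the step lies within the scatter and gives neither compound the edge. No evidence shown here bears on why the exchange leaves the number within the scatter.

The compounds shown leave open whether a group of another kind at this position, such as an amine or a carboxylic acid, would move the number beyond the scatter. They also leave open whether the same exchange would read alike on the core of compound 3, as its 4-fluorophenyl counterpart is not among them.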